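Methoxy to Trifluoromethyl on Two Related Cores

The source may hold more compounds than are shown below. What is called first, only, known or untested is meant among the compounds shown, and "the series" means these compounds.

Compound 1 `COc1ccc(C(=O)NC(CCN(C)C)c2ccc(Cl)cc2)cc1` and compound 2 `CN(C)CCC(NC(=O)c1ccc(C(F)(F)F)cc1)c1ccc(Cl)cc1` share a core that carries an amide, and they differ only in one spot: trifluoromethyl in place of methoxy on an aromatic carbon. In an assay on NIH3T3 cells with Urotensin-2 receptor (Homo sapiens) as the target (on this read-out lower numbers stand for an effect already at smaller amounts and higher numbers for an effect only at larger amounts of compound), compound 1 gives 1350 nM, while compound 2 gives 77.6 nM, so that the change made a 17-fold lower number from compound 1 to compound 2 (1.24 log units; beyond the scatter). Compound 3 `COc1ccc(NC(=O)NC(CCN(C)C)c2ccc(Cl)cc2)cc1` carries a urea instead; the difference between the core of compound 3 and the core of compound 1 is not broken down here. In this assay compound 3 gives 2000 nM, which stands close to the value of compound 1 and far from that of compound 2. Compound 4 `CN(C)CCC(NC(=O)Nc1ccc(C(F)(F)F)cc1)c1ccc(Cl)cc1` stands to compound 3 exactly as compound 2 stands to compound 1, the same change in the same place: trifluoromethyl in place of methoxy on an aromatic carbon. Because the earlier pair showed a 17-fold lower number from compound 1 to compound 2 (1.24 log units; beyond the scatter), the same change is expected to lower the number again, and compound 4 is estimated at 150 nM, a step of a 13-fold lower number from compound 3 to compound 4 (1.12 log units; beyond the scatter), with a range from 40 nM to 600 nM.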

Compound 4, half-maximal effective concentration: 117 nM
Beside the measured number, compound 4's estimate is 1.3-fold (0.11 log units) above it; the measured number falls inside the stated range.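

In this assay, replacing methoxy with trifluoromethyl on the core that carries a urea gives a 17-fold lower number from compound 3 to compound 4 (1.23 log units; beyond the scatter), and this step matches the one seen on the core that carries an amide: the same change on two cores in this assay, a 17-fold lower number (1.24 log units; beyond the scatter) from compound 1 to compound 2 and a 17-fold lower number (1.23 log units; beyond the scatter) from compound 3 to compound 4, 1.0-fold (0.01 log units) apart, within the scatter of two such steps. Within this series, then, the change carried over from the core of compound 1 to the core of compound 3 with its size unchanged, so the amide and the urea made no visible difference to this one exchange. Within the data shown here, this rests on only two pairs, a single place on the aromatic ring and a single read-out, so it does not show that the step would hold on any other core or for any other exchange, and it does not explain why the two steps agree.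

The compounds shown leave open what a nitrile or a fluorine in that same place would do on either core. They also leave open how either core would respond with a carboxylic acid in place of the dimethylamino group.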